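This account rests on a few compounds, and the source may have more. Where it says the series, first, only, none or still open, it means among the compounds named here.

Three prenylated chalcones sharing one core have been examined for cytotoxicity: compound 1 `COc1ccc(/C=C/C(=O)c2c(OC)cc(OC)c(CC=C(C)C)c2O)cc1`, compound 2 `COc1cc(OC)c(C(=O)/C=C/c2cc(OC)c(OC)c(OC)c2)c(O)c1CC=C(C)C` and compound 3 `COc1cc(OC)c(C(=O)/C=C/c2ccc(OC)c(OC)c2OC)c(O)c1CC=C(C)C`. In an ADME assay on MCF7-DOX cells (Homo sapiens) for cytotoxicity, read by MTT assay, with a stated time of 48 h (on this read-out higher numbers stand for weaker inhibition and lower numbers for stronger inhibition), compound 1 gives 46900 nM, compound 2 gives 74900 nM and compound 3 gives 62700 nM. The number for compound 1 is the lowest of the three, yet its gaps to compound 3 and to compound 2 both lie within the scatter, so the three stand together. Compound 4 `COc1cc(OC)c(C(=O)/C=C/c2ccc(F)cc2)c(O)c1CC=C(C)C` differs from compound 1 in one place: fluoro in place of methoxy on an aromatic carbon. For the measured compounds named here, with no measured step to lean on, and three close numbers, the estimated step of a 1.2-fold higher number from compound 1 to compound 4 (0.07 log units; within the scatter) is expected to stay within the scatter. In this assay compound 4 is therefore expected to give about 55000 nM, within a range from 25000 nM to 120000 nM.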

Compound 4, half-maximal inhibitory concentration: 53700 nM
For compound 4 the middle estimate is 1.0-fold (0.01 log units) above the measured one; the range from low to high includes it.
By their numbers in this assay, from the lowest: compounds 1, 4, 3 and 2 (each within the scatter of the next).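

For the compounds shown here, this is the first single-place step at this position: in this assay, fluoro in place of methoxy gives a 1.1-fold higher number from compound 1 to compound 4 (0.06 log units; within the scatter) on the six-membered aromatic ring. On this one exchange, then, the methoxy and its hydrogen-bond acceptor can be replaced by a single fluorine atom without a step beyond the scatter. Nothing available here gives a reason for this result.

The compounds shown leave open whether any group at this position would move the number beyond the scatter. As far as these compounds go, an amine, a carboxylic acid or a longer alkoxy chain there remains untested among them.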